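Working notes: aromatic group swaps on the shared core

This account rests on a few compounds, and the source may have more. Where it says the series, first, only, none or still open, it means among the compounds named here.

compound 1 `COC1=C(C)C(=O)/C(=C(O)/C=C/c2cccc(OC)c2)C(=O)C1(C)C` gives 3.3 ug/mL
compound 2 `COC1=C(C)C(=O)/C(=C(O)/C=C/c2ccc(C)cc2)C(=O)C1(C)C` gives 3.9 ug/mL
compound 3 `CCc1ccc(/C=C/C(O)=C2/C(=O)C(C)=C(OC)C(C)(C)C2=O)cc1` gives 6.9 ug/mL

In a functional assay on KB cells (Homo sapiens) for cytotoxicity (on this read-out lower numbers stand for an effect already at smaller amounts and higher numbers for an effect only at larger amounts of compound), compound 3 gives 6.9 ug/mL as its number. The gap to its nearest neighbour is small (a 1.8-fold higher number from compound 2 to compound 3 (0.25 log units; within the scatter)) and the gap to its furthest is modest (a 2.1-fold higher number from compound 1 to compound 3 (0.32 log units; beyond the scatter)).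

The next compound is compound 4 `C=Cc1ccccc1/C=C/C(O)=C1/C(=O)C(C)=C(OC)C(C)(C)C1=O` with a single change to the group on the chain (2-vinylphenyl in place of 4-ethylphenyl on a double-bonded chain carbon bound to a double-bonded chain carbon).

The measured steps that bear on this are the other changes at that same place. One swap stays small (a 1.2-fold higher number from compound 1 to compound 2 (0.07 log units; within the scatter)) and the largest swap seen so far is the modest one already noted. For the measured compounds named here, no measured compound carries 2-vinylphenyl, so the data give only the general size of swaps at this place and not the effect of this group. The three numbers stay close together, and compound 3 at 6.9 ug/mL sits at the far end from compound 1 at 3.3 ug/mL in this small set. A small drift back towards the middle of that spread is therefore expected, but no change beyond the scatter. The estimated step in this assay is a 1.5-fold lower number from compound 3 to compound 4 (0.19 log units; within the scatter) and its direction is only weakly supported. For compound 4 the estimated value is 4.5 ug/mL with an expected range (1.5 ug/mL to 13 ug/mL).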

Compound 4, concentration for half-maximal effect: 1.9 ug/mL
For compound 4 the middle estimate is 2.4-fold (0.37 log units) above the measured one, and the stated range covers the measured number.
By their numbers in this assay, from the lowest: compounds 4, 1, 2 and 3 (each within the scatter of the next, the first and the last beyond it).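

In this assay, the change at this place on a double-bonded chain carbon bound to a double-bonded chain carbon gives the largest step seen so far: 2-vinylphenyl in place of 4-ethylphenyl (a 3.6-fold lower number from compound 3 to compound 4 (0.56 log units; beyond the scatter)), although both groups have the same heavy-atom count, all carbon, and one aromatic ring, and only the entering group has a double bond outside aromatic rings. The same group in place of 4-methylphenyl also gives a step beyond the scatter (a 2.1-fold lower number from compound 2 to compound 4 (0.31 log units; beyond the scatter)), whereas in place of 3-methoxyphenyl it stays within the scatter (a 1.7-fold lower number from compound 1 to compound 4 (0.24 log units; within the scatter)), so compound 4 separates from compound 2 and compound 3 but not from compound 1. No measurement at hand gives a cause for these steps.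

On these data alone, it remains open whether 2-ethylphenyl or 4-vinylphenyl would read like compound 3 or like compound 4, so the contribution of the vinyl double bond cannot be separated from that of the substituent's location on the ring. Also open, as far as these compounds go, is how a phenyl group carrying an amine or a carboxylic acid would read at this place.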